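The source may hold more compounds than are shown below. What is called first, only, known or untested is meant among the compounds shown, and "the series" means these compounds.

Of the compounds shown here, two of a shared core have been measured in an assay on isolated protein for inhibition of Amine oxidase [flavin-containing] A (Homo sapiens), read by fluorescence and Amplex Red, with a stated time of 30 min; on this read-out lower numbers stand for stronger inhibition and higher numbers for weaker inhibition. Compound 1 `Cc1ccc(-c2csc(N/N=C/c3ccc(N4CCCC4)cc3)n2)cc1` gives 20000 nM and stands highest of the two numbers. Its nearest neighbour is compound 2 `Fc1ccc(-c2csc(N/N=C/c3ccc(N4CCCC4)cc3)n2)cc1`, and compound 2 gives 13100 nM. Among the measured compounds shown here, the only step between measured compounds, a 1.5-fold lower number from compound 1 to compound 2 (0.18 log units; within the scatter), is the exchange of a methyl for a fluoro on the aromatic carbon, and it lies within the scatter, so the two values cannot be told apart.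

Compound 3 `Fc1ccc(-c2csc(N/N=C/c3ccc(N4CCCC4)cc3)n2)c(F)c1` has not yet been measured. It differs from compound 1 by 2,4-difluorophenyl in place of 4-methylphenyl on an aromatic carbon. This change contains the change from compound 1 to compound 2 and adds a second fluorine to the same ring. For the measured compounds named here, the one step that bears on it, a 1.5-fold lower number from compound 1 to compound 2 (0.18 log units; within the scatter), was within the scatter, and no measured pair shows the effect of the second fluorine. The step of a 1.7-fold lower number from compound 1 to compound 3 (0.22 log units; within the scatter) is therefore expected to be small, with any lean toward a lower number resting only on the direction seen in compound 2 at 13100 nM. For compound 3 in this assay the estimate is 12000 nM, with a range from 5000 nM to 30000 nM.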

Compound 3, half-maximal inhibitory concentration: 15600 nM
Beside the measured number, compound 3's estimate is 1.3-fold (0.11 log units) below it; measured number inside the range.
By their numbers in this assay, from the lowest: compounds 2, 3 and 1 (each within the scatter of the next).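

Among the compounds shown here, the second fluorine was the one change no earlier pair could speak to, and in this assay it gives a 1.2-fold higher number from compound 2 to compound 3 (0.08 log units; within the scatter). The larger exchange of 4-methylphenyl for 2,4-difluorophenyl, on an aromatic carbon of the five-membered aromatic ring with 1 nitrogen and 1 sulfur, gives a 1.3-fold lower number from compound 1 to compound 3 (0.11 log units; within the scatter) and so also stays small. Compounds 1, 2 and 3 therefore cannot be told apart, which shows that these methyl and fluoro variations on the phenyl ring leave the reading essentially unmoved, and nothing available explains why the values lie so close together.

The compounds shown carry only methyl and fluoro groups on this ring, so it remains open whether an amine, a carboxylic acid or a longer alkyl chain there would shift the number beyond the scatter. On these data alone, it is equally open whether an unsubstituted phenyl ring would read like these three, or whether replacing the phenyl ring with a pyridine ring would matter.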